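The source may hold more compounds than are shown below. What is called first, only, known or untested is meant among the compounds shown, and "the series" means these compounds.

Compound 1 `C=CC(=O)N[C@@H]1CCCN(S(=O)(=O)c2ccc(NC(=O)OCc3ccccc3)cc2)C1`: > 6 h
Compound 2 `C=CC(=O)N[C@H]1CCN(S(=O)(=O)c2ccc(NC(=O)OCc3ccccc3)cc2)C1`: > 6 h
Compound 3 `C=CC(=O)NC1CCN(S(=O)(=O)c2ccc(C(=O)NCCCc3ccccc3)cc2)CC1`: > 6 h

All three values come from an ADME assay on a cell-free system (plasma, Mus musculus) for metabolic stability, tested at 1 uM (on this read-out lower numbers stand for a shorter-lived compound and higher numbers for a longer-lived compound), and none of them is an exact number. In this assay compound 3 gives > 6 h, which is a limit of the assay. It shares that position with the other two compounds, and the whole picture so far is the limit of > 6 h in this assay, at which 3 of the 3 values shown sit.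

Compound 4 `C=CC(=O)NC1CCN(S(=O)(=O)c2ccc(C(=O)NCCC3CCCCC3)cc2)CC1` changes compound 3 in one place: cyclohexyl in place of benzyl on a saturated chain carbon, two bonds along the chain from an amide-type nitrogen. Put simply, cyclohexyl stands in place of benzyl on a saturated chain carbon, two bonds along the chain from an amide-type nitrogen.

Among the compounds with values here, no measured pair shows this change, so the data give no direct size for it. With compound 3 at > 6 h, compound 4 is expected to remain long-lived in this assay, with no change beyond the scatter. The expected result is a step that the limit leaves unreadable from compound 3 to compound 4. For compound 4 the estimate is 7 h, with an expected range from 4 h to 12 h.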

Compound 4, half-life: > 6 h
Compound 4 was reported as a limit; the forecaster's own chance of this, stated with the estimate: 85%; the middle value is on the limit's open side.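

Compound 3 and compound 4 both sit at a limit of the assay rather than at exact numbers, so no step between them can be read: the limit of > 6 h in this assay, at which 4 of the 4 values shown sit.

On these data alone, how long any of the four compounds really lasts, and whether cyclohexyl in place of benzyl alters that, stays open.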